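Series notes: aryl ether variation in the benzyloxy arm

The source may report more compounds than this note shows. Statements on the series, on what has been measured and on what is new or still open speak of the compounds shown alone.

Compound 3 `CC(C)(N)C(=O)N[C@H](COCc1cccc(OC(F)(F)F)c1)c1nnnn1CCOC(=O)NCCCCO` gives 3.1 nM in a functional assay on cells for inhibition of growth hormone secretagogue receptor type 1 (Homo sapiens), read by FLIPR and calcium flux; a lower number here means that less compound is needed, a higher number that more compound is needed for the effect. Among the three compounds measured it stands second highest; its nearest neighbour is compound 1 `CC(C)(N)C(=O)N[C@H](COCc1cccc(Cl)c1)c1nnnn1CCOC(=O)NCCCCO`, which in this assay gives 1.6 nM, and its furthest is compound 2 `CC(C)(N)C(=O)N[C@H](COCc1cc(C(F)(F)F)cc(C(F)(F)F)c1)c1nnnn1CCOC(=O)NCCCCO`, which in this assay gives 34 nM. For the measured compounds named here, the one step measured in a single place, a 1.9-fold higher number from compound 1 to compound 3 (0.29 log units; within the scatter), is within the scatter. The pair of compound 3 and compound 2 shows that a ring carrying two trifluoromethyl groups gives a clearly higher number than the trifluoromethoxy ring.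

Compound 4 `CC(C)(N)C(=O)N[C@H](COCc1ccccc1-c1ccccc1)c1nnnn1CCOC(=O)NCCCCO` differs from compound 3 as follows: 2-phenylphenyl in place of 3-(trifluoromethoxy)phenyl on a saturated chain carbon bound to an oxygen on a saturated carbon. Going by the values given here, no measured step tracks this change directly; the only bearing comes from compound 2, whose value 34 nM shows that a heavier aryl group can raise the number well beyond the scatter. A biphenyl group adds comparable bulk, so a rise is expected for compound 4, of the order of a 4.8-fold higher number from compound 3 to compound 4 (0.68 log units; beyond the scatter). The estimate for compound 4 is 15 nM, within 4 nM to 60 nM.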

Compound 4, half-maximal effective concentration: 0.34 nM
Compound 4: the middle estimate sits 44-fold (1.64 log units) above what was measured, outside the stated range (below it).
By their numbers in this assay, from the lowest: compound 4; then compounds 1 and 3 (each within the scatter of the next); then compound 2.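

Set on the saturated chain carbon bound to an oxygen on a saturated carbon, 2-phenylphenyl brings the number down against both single-ring groups: a 9.1-fold lower number from compound 3 to compound 4 (0.96 log units; beyond the scatter) and a 4.7-fold lower number from compound 1 to compound 4 (0.67 log units; beyond the scatter) are both beyond the scatter. A heavier aryl group therefore does not of itself raise the number in this assay, for compound 2 gives 34 nM while compound 4 gives 0.34 nM in the same assay. Nothing available accounts for the drop with 2-phenylphenyl.

The compounds shown leave open whether the second phenyl ring needs to stay where it stands in 2-phenylphenyl, as this is the only two-ring group here. They also leave open how a pyridine ring in its place, or a methoxy group or an amine on that second ring, would read in this assay.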